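Series notes: chain variation on the shared core, step to compound 3

This account rests on a few compounds, and the source may have more. Where it says the series, first, only, none or still open, it means among the compounds named here.

Among the measured compounds shown here, compound 2, `N#Cc1c(N2CCN(c3ncccn3)CC2)ccn2c(CC(F)(F)F)cnc12`, is the only member of this set with a numerical result in a functional assay on CHO cells with metabotropic glutamate receptor 2 (Homo sapiens) as the target, read by GTPgammaS binding; on this read-out higher numbers stand for an effect only at larger amounts of compound and lower numbers for an effect already at smaller amounts; in this assay compound 2 gives 851 nM. Compound 1, `CCc1cnc2c(C#N)c(N3CCN(c4ncccn4)CC3)ccn12`, returns only a limit, > 3160 nM, which is the edge of the assay and not a number (the limit of > 3160 nM in this assay, at which 1 of the 2 values shown sits). For the measured compounds named here, the one measured step, an at least 3.7-fold lower number from compound 1 to compound 2 (0.56 log units; beyond the scatter), therefore reads as a lower bound.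

Compound 3, `N#Cc1c(N2CCN(c3ncccn3)CC2)ccn2c(CCC3CC3)cnc12`, differs from compound 2 by cyclopropylmethyl in place of trifluoromethyl on a saturated chain carbon bound to an aromatic carbon. Going by the values given here, no measured pair shows this exchange; the step from compound 1 to compound 2 touches the same chain carbon but with trifluoromethyl entering rather than leaving, so it bears on the present change only by showing that this position is sensitive and that the trifluoromethyl variant sits well inside the measurable range. Whether cyclopropylmethyl holds that gain is not decided by anything shown here.

The expectation for compound 3 is a value close to that of compound 2, within the scatter, estimated at 700 nM with a range from 150 nM to 3000 nM. The estimated step this implies is a 1.2-fold lower number from compound 2 to compound 3 (0.08 log units; within the scatter), an expected change that stays within the scatter.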

Compound 3, half-maximal effective concentration: 1100 nM
Compound 3: the middle estimate sits 1.6-fold (0.20 log units) below what was measured, within the range that was stated.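

The exchange on the saturated chain carbon bound to an aromatic carbon gives a 1.3-fold higher number from compound 2 to compound 3 (0.11 log units; within the scatter), so in this assay trifluoromethyl and cyclopropylmethyl cannot be told apart, and fluorine is not required for a numerical result at this place. Compound 3 also stands clear of compound 1, with an at least 2.8-fold lower number from compound 1 to compound 3 (0.45 log units; beyond the scatter), so the separation from compound 1 no longer rests on trifluoromethyl alone, and two groups with 4 heavy atoms each, one of them all carbon with a three-membered ring, share it. Compound 1 has only a limit and not a number, so both separations from it are lower bounds and their true size stays unknown: the limit of > 3160 nM in this assay, at which 1 of the 3 values shown sits.

The two groups compared here have 0 hydrogen-bond donors, 0 hydrogen-bond acceptors and no net charge, so the compounds shown leave open how an amine, a hydroxyl or a carboxylic acid at this place would read in this assay. Also open, as far as these compounds go, is whether a longer chain or a larger ring such as cyclohexyl would keep a numerical result or return to a limit.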